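The source may report more compounds than this note shows. Statements on the series, on what has been measured and on what is new or still open speak of the compounds shown alone.

Compound 1 `CCN(CC)C(=O)CN(c1ccc(C)cc1)S(=O)(=O)c1ccc(OC)c(OC)c1` — > 10000 nM in a functional assay on CHO cells for inhibition of Orexin/Hypocretin receptor type 1 (Homo sapiens), read by FLIPR and calcium flux; a lower number here means a stronger inhibitor, a higher number a weaker inhibitor; compound 2 `CCN(C(=O)CN(c1cc(N(C)C)ccc1Cl)S(=O)(=O)c1ccc(OC)c(OC)c1)c1cccc(C)n1` — 17 nM; compound 3 `CCN(C(=O)CN(c1cc(N(C)C)ccc1Cl)S(=O)(=O)c1ccc(OC)c(OC)c1)c1cnc(C)cn1` — 5 nM.

For compound 1 the value is only a limit of the assay, (the limit of > 10000 nM in this assay, at which 1 of the 3 values shown sits), so its true position is not known. Compound 4 `CCN(CC)C(=O)CN(c1cc2c(C)nsc2cc1Cl)S(=O)(=O)c1ccc(OC)c(OC)c1` arises from compound 1 by a group of 11 heavy atoms (8 carbon, 1 nitrogen, 1 sulfur, 1 chlorine; one five-membered aromatic ring with 2 hetero atoms, one six-membered aromatic ring of carbon only) in place of a group of 7 heavy atoms (7 carbon; one six-membered aromatic ring of carbon only), on a sulfonamide nitrogen. Going by the values given here, no measured step bears on this change: the only measured step, a 3.4-fold lower number from compound 2 to compound 3 (0.53 log units; beyond the scatter), concerns the amide-type nitrogen, and compounds 2 and 3 differ from compound 1 in two places at once, so their values alone show that a chlorine-bearing aryl on the sulfonamide nitrogen is compatible with strong inhibition. The estimated value for compound 4 is 1500 nM (range 200 nM to 10000 nM), an expected step of an at least 6.6-fold lower number from compound 1 to compound 4 (0.82 log units; beyond the scatter), with the direction uncertain.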

Compound 4, half-maximal inhibitory concentration: 29 nM
Estimate against measurement, compound 4: 52-fold (1.71 log units) above; the whole stated range lies above it.
By their numbers in this assay, from the lowest: compound 3; then compounds 2 and 4 (each within the scatter of the next). At a limit, above all of these: compound 1.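

The change on the sulfonamide nitrogen alone gives an at least 340-fold lower number from compound 1 to compound 4 (2.53 log units; beyond the scatter). The amide-type nitrogen keeps the two ethyl groups of compound 1, so neither 6-methylpyridin-2-yl nor 5-methylpyrazin-2-yl is needed there for strong inhibition. The value of compound 1 is a limit, so the true size of this step stays unknown: the limit of > 10000 nM in this assay, at which 1 of the 4 values shown sits.

On these data alone, it remains open which part of the entering group carries the step, the chlorine or the five-membered ring, and whether a bromine could replace that chlorine. Also open, as far as these compounds go, is how 5-methylpyrazin-2-yl on the amide-type nitrogen would combine with this group.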